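Exchanging 1,3-thiazol-5-yl for pyridin-3-yl

A few compounds are considered here, and "the series" means these few. Any claim that something is new, unique, unknown or untested is made for them only; others in the source may bear on it.

In a functional assay (plasma) for inhibition, with Rattus norvegicus as the target (on this read-out higher numbers stand for weaker inhibition and lower numbers for stronger inhibition), compound 1 (`C/C(=C\c1ccc(Cc2cncs2)cc1)C(=O)O`) gives 220 nM as the lower of two measured numbers, and compound 2 (`O=C(O)/C=C/c1ccc(Cc2cncs2)cc1`) gives 1500 nM as the higher. Compound 3 (`C/C(=C\c1ccc(Cc2cccnc2)cc1)C(=O)O`) carries pyridin-3-yl in place of 1,3-thiazol-5-yl on a saturated chain carbon bound to an aromatic carbon. Within the data shown here, the only measured step (a 6.8-fold higher number from compound 1 to compound 2 (0.83 log units; beyond the scatter)) puts 2-carboxyethenyl in place of 2-carboxyprop-1-en-1-yl on an aromatic carbon, a different change, so it hints at size but not direction. A similar size is expected, tentatively toward a lower number, giving an expected step (a 3.7-fold lower number from compound 1 to compound 3 (0.56 log units; beyond the scatter)) in this assay as a rough guess. Compound 3 is estimated at 60 nM within a range from 15 nM to 250 nM for now.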

Compound 3, half-maximal inhibitory concentration: 150 nM
Compound 3: the middle estimate sits 2.5-fold (0.40 log units) below what was measured; the range from low to high includes it.
By their numbers in this assay, from the lowest: compounds 3 and 1 (each within the scatter of the next); then compound 2.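

In this assay, pyridin-3-yl in place of 1,3-thiazol-5-yl gives a 1.5-fold lower number from compound 1 to compound 3 (0.17 log units; within the scatter), so the two rings cannot be told apart at this position. On a saturated chain carbon bound to an aromatic carbon, a six-membered aromatic ring with 1 hetero atom thus serves as well as a five-membered one with 2 hetero atoms, while the earlier step concerned only the 2-carboxyprop-1-en-1-yl group. Nothing available explains this match. Going by these compounds, whether a plain phenyl ring would keep the number in the same range remains open, as does whether pyridin-3-yl would still do so alongside 2-carboxyethenyl.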